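Cyano for Fluoro on the Naphthalene of Compound 3

The compounds below may be only part of what the source reports. "The series", "measured", "known", "first", "only" and "open" are said of these compounds alone.

Within the data shown here, compound 3 `C[C@H]1CN(c2cccc3cc(F)ccc23)CCN1CC[C@H]1OCc2cc(C(N)=O)ccc21` gives 67 nM in an in vitro assay on cells for displacement of a labelled ligand from 5-hydroxytryptamine receptor 1D (Homo sapiens) (a higher number here means a weaker inhibitor, a lower number a stronger inhibitor), the highest number among the three compounds measured so far. Compound 2 `C[C@H]1CN(c2cccc3cc(F)ccc23)CCN1CC[C@@H]1OCc2cc(C(N)=O)ccc21` gives 14 nM in this assay, and compound 1 `N#Cc1ccc2c(N3CCN(CC[C@@H]4OCCc5cc(C(N)=O)ccc54)CC3)cccc2c1` gives 1 nM. Among the measured compounds shown here, the only measured step between two compounds that differ in a single place is a stereochemical one: a 4.8-fold higher number from compound 2 to compound 3 (0.68 log units; beyond the scatter), and these two compounds differ only in configuration as drawn (the fact that compounds 2 and 3 differ only in the configuration as drawn).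

Compound 4 `C[C@H]1CN(c2cccc3cc(C#N)ccc23)CCN1CC[C@H]1OCc2cc(C(N)=O)ccc21` is compound 3 with cyano in place of fluoro on an aromatic carbon. For the measured compounds named here, no measured pair differs by this exchange alone, so the step from compound 3 to compound 4 has no direct precedent in these data. Compound 1 carries the cyano group and gives 1 nM in this assay, but it differs from compound 3 in several other places as well, so its value cannot be read as evidence on this exchange by itself. The expectation is therefore a step that stays within the scatter, with a slight lean toward a lower number: a 1.7-fold lower number from compound 3 to compound 4 (0.22 log units; within the scatter) is what is expected. Compound 4 is estimated at 40 nM, with a range from 12 nM to 130 nM.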

Compound 4, inhibition constant: 1.8 nM
The estimate for compound 4 lay 22-fold (1.35 log units) above the measured number; the measured number lies below the stated range.
By their numbers in this assay, from the lowest: compounds 1 and 4 (each within the scatter of the next); then compound 2; then compound 3.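

In this assay, cyano in place of fluoro on this aromatic carbon gives a 37-fold lower number from compound 3 to compound 4 (1.57 log units; beyond the scatter). Among these compounds, this is the first measured exchange at this position, and it shows that the position, meta to a fused ring and para to a fused ring, responds strongly to the group it carries, which the earlier compounds could not show. The step is also larger than the only other single-place step, a 4.8-fold higher number from compound 2 to compound 3 (0.68 log units; beyond the scatter), and it was read on compound 3, the member of the stereochemical pair with the higher number: the fact that compounds 2 and 3 differ only in the configuration as drawn

The compounds shown leave open whether the same exchange would give a step of similar size on compound 2, and whether the drop in the number is particular to cyano or would also appear with chloro, a methyl group or a carboxamide on this carbon. They also hold no measured property that would tie the step to a cause, so the reason for its size remains unknown.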